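From cyclohexyl to pyridin-4-yl: what to expect

A few compounds are considered here, and "the series" means these few. Any claim that something is new, unique, unknown or untested is made for them only; others in the source may bear on it.

compound 1 `O=C(C1CCCC1)N1N=CCC1c1ccccc1`: 5.4
compound 2 `O=C(C1CCOC1)N1N=CCC1c1ccccc1`: 3
compound 3 `O=C(C1CCCCC1)N1N=CCC1c1ccccc1`: 5.9

These values come from a physicochemical assay for lipophilicity, read by HPLC, measured as chromatographic lipophilicity, at pH 7.4; on this read-out lower numbers stand for lower lipophilicity and higher numbers for higher lipophilicity. Of the three, compound 3 stands highest at 5.9. The next compound, compound 4 `O=C(c1ccncc1)N1N=CCC1c1ccccc1`, keeps the shared core and changes one group: pyridin-4-yl in place of cyclohexyl on a carbonyl carbon.

Among the measured compounds shown here, no measured step makes this exact swap. The closest guides are the two steps involving oxolan-3-yl, the only measured ring with a hetero atom. The data show a number 2.90 log units higher from compound 2 to compound 3 (beyond the scatter) and a number 2.40 log units lower from compound 1 to compound 2 (beyond the scatter), and both are large. Swapping one carbon-only ring for another gave a much smaller change, a number 0.50 log units higher from compound 1 to compound 3 (beyond the scatter), which is modest. For the measured compounds named here, no measured compound carries an aromatic ring in this place, so the size of the new step is uncertain.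

A large fall is therefore expected, and the estimated step is a number 2.30 log units lower from compound 3 to compound 4 (beyond the scatter). For compound 4 the expected value is 3.6, with an estimated range from 2.8 to 4.4.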

Compound 4, distribution coefficient: 2.7
Beside the measured number, compound 4's estimate is 0.90 log units above it, outside the stated range (below it).
By their numbers in this assay, from the lowest: compounds 4 and 2 (each within the scatter of the next); then compound 1; then compound 3.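

In this assay, the first aromatic ring at this place, on a carbonyl carbon, again sits far from the carbon-only rings (a number 3.20 log units lower from compound 3 to compound 4 (beyond the scatter); a number 2.70 log units lower from compound 1 to compound 4 (beyond the scatter)). Against the other ring holding a hetero atom the result is different (a number 0.30 log units lower from compound 2 to compound 4 (within the scatter)), so compound 4 and compound 2 cannot be told apart here, although one ring is aromatic and the other is not. Nothing measured here says why these two different rings give such similar numbers.

The compounds shown cannot separate the effect of the ring nitrogen from that of aromaticity: a plain phenyl ring, with carbon atoms only, could stay with compound 3 or fall with compound 4. Going by these compounds, how an open chain, or a ring carrying an amine or a carboxylic acid, would behave at this place also remains open.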